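A few compounds are considered here, and "the series" means these few. Any claim that something is new, unique, unknown or untested is made for them only; others in the source may bear on it.

Measured compounds:
compound 1 `COC(=O)c1cccc(-c2cnc3[nH]cc(-c4ccccc4)c3c2)c1`: 123 nM
compound 2 `COC(=O)c1cccc(-c2cnc3[nH]cc(-c4cncnc4)c3c2)c1`: 62.5 nM

In an assay on isolated protein for inhibition of serine/threonine-protein kinase Nek1 (Homo sapiens), read by radiometric assay and 33P incorporation, in the presence of a further agent that is not named here (a higher number here means a weaker inhibitor, a lower number a stronger inhibitor), compound 1 gives 123 nM. Compound 2, with pyrimidin-5-yl in place of phenyl on the same aromatic carbon, gives 62.5 nM. Among the compounds with values here, the only step between them, a 2.0-fold lower number from compound 1 to compound 2 (0.29 log units; within the scatter), lies within the scatter, so compound 2 holds the lower of the two numbers without standing apart from compound 1 beyond repeat variation.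

Compound 3 `COC(=O)c1cccc(-c2cnc3[nH]cc(-c4cccnc4)c3c2)c1` is the next member: pyridin-3-yl in place of pyrimidin-5-yl on an aromatic carbon. The entering pyridin-3-yl keeps one ring hetero atom and one hydrogen-bond acceptor where pyrimidin-5-yl carried two, so it falls within the same small set of aryl groups already spanned by compound 1 and compound 2. Within the data shown here, the one measured step that bears on this change, a 2.0-fold lower number from compound 1 to compound 2 (0.29 log units; within the scatter), is itself within the scatter, which gives no ground to expect a shift beyond the scatter in this assay in either direction. Compound 3 is therefore expected to give about 85 nM, with a range of 35 nM to 200 nM, an expected step of a 1.4-fold higher number from compound 2 to compound 3 (0.13 log units; within the scatter).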

Compound 3, half-maximal inhibitory concentration: 11.5 nM
The estimate for compound 3 lay 7.4-fold (0.87 log units) above the measured number; measured number below the stated range.
By their numbers in this assay, from the lowest: compound 3; then compounds 2 and 1 (each within the scatter of the next).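

In this assay, within the data shown here, pyridin-3-yl in place of pyrimidin-5-yl on this aromatic carbon gives a 5.4-fold lower number from compound 2 to compound 3 (0.74 log units; beyond the scatter), and pyridin-3-yl in place of phenyl gives an 11-fold lower number from compound 1 to compound 3 (1.03 log units; beyond the scatter), so a position where the only earlier step stayed within the scatter now proves sensitive to the choice of six-membered aromatic ring. The ring with 1 hetero atom stands apart from both the ring with none and the ring with 2 hetero atoms, so across these three compounds the number does not simply follow the count of ring nitrogens in one direction. Nothing measured here accounts for what sets pyridin-3-yl apart from the other two groups.

The compounds shown leave open whether this step belongs to pyridin-3-yl alone or would also appear with pyridin-4-yl or pyridin-2-yl, which would show whether the place of the ring nitrogen matters and not only its presence. Also open, going by these compounds, is whether an amine or a methoxy group on the pyridin-3-yl ring would keep the low number, and whether the step survives when the methyl ester gives way to a carboxylic acid or an amide.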